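Phenyl to pentyl on the amine side chain

The source may report more compounds than this note shows. Statements on the series, on what has been measured and on what is new or still open speak of the compounds shown alone.

Compound 3 `OC[C@H]1OC(n2cnc3c(NCc4ccccc4)nccc32)[C@H](O)[C@@H]1O` is the point of departure. In a functional assay (Homo sapiens) for inhibition of Nucleic Acid, tested at 100 uM (on this read-out higher numbers stand for more inhibition at the one concentration tested (going by the name of the read-out) and lower numbers for less inhibition), compound 3 gives 32%, the highest of the three numbers measured. Its nearest neighbour is compound 2 `OC[C@H]1O[C@@H](n2cnc3c(Cl)nccc32)C[C@@H]1O`, which in this assay gives 5%, a gap beyond the scatter. Compound 1 `CN(C)c1nccc2c1ncn2[C@H]1C[C@H](O)[C@@H](CO)O1` in this assay gives 0%, the furthest from compound 3 and again beyond the scatter.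

Among the compounds with values here, the one measured single-point step, a number 5 percentage points higher from compound 1 to compound 2 (within the scatter), lies within the scatter and concerns a different place on the core than the change now at hand, so it does not inform the step to compound 4.

Compound 4 `CCCCCCNc1nccc2c1ncn2C1O[C@H](CO)[C@@H](O)[C@H]1O` differs from compound 3 by pentyl in place of phenyl on a saturated chain carbon bound to a nitrogen on an aromatic ring; cut one bond further out this reads benzylamino to hexylamino. Within the data shown here, no measured pair covers a phenyl-to-pentyl swap, and no pair covers any change at that saturated chain carbon. Without a matching step, the working expectation for this assay is a step from compound 3 to compound 4 of no size beyond the scatter in either direction, that is a number 7 percentage points lower from compound 3 to compound 4 (within the scatter) as the estimated step. For compound 4 the estimate in this assay is therefore 25%, with a range from 5% to 50% to reflect the absence of any anchoring comparison.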

Compound 4, a percentage reported as inhibition, at one concentration (the size of the read-out at that concentration, not a potency): 8%
The estimate for compound 4 lay 17 percentage points above the measured number; measured number inside the range.
By their numbers in this assay, from the lowest: compounds 1, 2 and 4 (each within the scatter of the next); then compound 3.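

In this assay, the amine side chain is not a silent position: pentyl in place of phenyl on a saturated chain carbon bound to a nitrogen on an aromatic ring gives a number 24 percentage points lower from compound 3 to compound 4 (beyond the scatter). Of the two single-place steps in hand, only this one lies beyond the scatter; the other, a number 5 percentage points higher from compound 1 to compound 2 (within the scatter), concerns a different place on the core and gave no view of this side chain. No measurement in hand accounts for the loss, so the step stands as an observation about this pair alone.

A single step cannot separate the loss of the aromatic ring from the change to an open chain, since benzylamino to hexylamino alters both at once, and a cyclohexyl group in place of phenyl would pull the two apart. Also open, going by these compounds, is whether a shorter or longer chain, or a phenyl ring carrying a methoxy group or an amine, would hold or exceed the level of compound 3 at 32% in this assay.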